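The source may report more compounds than this note shows. Statements on the series, on what has been measured and on what is new or still open speak of the compounds shown alone.

Going by the values given here, in a physicochemical assay for solubility, in phosphate buffer, with a stated time of 24 h, at pH 7.4, tested at 100 uM (a lower number here means a less soluble compound, a higher number a more soluble compound), three compounds that differ only in the group on a sulfonyl sulfur have numbers so far. Compound 1 `O=C(NCc1ccc(S(=O)(=O)c2cccc(C(F)(F)F)c2)cc1)N1Cc2ccncc2C1` gives 10000 nM, compound 2 `O=C(NCc1ccc(S(=O)(=O)c2cncc(C(F)(F)F)c2)cc1)N1Cc2ccncc2C1` gives 83000 nM, and compound 3 `CC(C)n1cc(S(=O)(=O)c2ccc(CNC(=O)N3Cc4ccncc4C3)cc2)cn1` gives 192000 nM, the highest of the three. Compound 4 `O=C(NCc1ccc(S(=O)(=O)C2CCOCC2)cc1)N1Cc2ccncc2C1` carries oxan-4-yl in place of 1-isopropyl-1H-pyrazol-4-yl on a sulfonyl sulfur. The measured steps at this place are an 8.3-fold higher number from compound 1 to compound 2 (0.92 log units; beyond the scatter), a 19-fold higher number from compound 1 to compound 3 (1.28 log units; beyond the scatter) and the smallest, a 2.3-fold higher number from compound 2 to compound 3 (0.36 log units; beyond the scatter). None of them brings in a non-aromatic ring, so they are only a rough guide, and neither direction is favoured. The expected change is small, an estimated 1.1-fold lower number from compound 3 to compound 4 (0.05 log units; within the scatter), which stays within the scatter. Compound 4 is estimated at 170000 nM, with an expected range from 70000 nM to 350000 nM.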

Compound 4, solubility: 206000 nM
Beside the measured number, compound 4's estimate is 1.2-fold (0.08 log units) below it; the measured number falls inside the stated range.
By their numbers in this assay, from the lowest: compound 1; then compound 2; then compounds 3 and 4 (each within the scatter of the next).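

In this assay a non-aromatic ring on the sulfonyl sulfur can now be compared with aromatic ones: the change to oxan-4-yl gives a 1.1-fold higher number from compound 3 to compound 4 (0.03 log units; within the scatter), so these two groups cannot be told apart. The same ring gives a 2.5-fold higher number from compound 2 to compound 4 (0.39 log units; beyond the scatter) and a 21-fold higher number from compound 1 to compound 4 (1.31 log units; beyond the scatter), so among these compounds an aromatic ring on this sulfur is not needed for the top numbers. Nothing available explains these differences. Going by these compounds, whether an amine such as piperidin-4-yl, a carboxylic acid or a plain methyl on this sulfur would give numbers this high remains open.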